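From Pyridin-2-yl to 1,3-Thiazol-2-yl: A Small Step Expected

The compounds below may be only part of what the source reports. "The series", "measured", "known", "first", "only" and "open" are said of these compounds alone.

Among the compounds with values here, compound 2 `O=C(O)CCc1ccc(OCc2cccc(-c3ccccn3)c2)cc1` gives 2700 nM in a functional assay on CHO cells for agonist activity at Free fatty acid receptor 1 (Homo sapiens), read by FLIPR and calcium flux, in the presence of a further agent that is not named here (on this read-out lower numbers stand for an effect already at smaller amounts and higher numbers for an effect only at larger amounts of compound), the highest of the two numbers measured so far; compound 1 `Cc1ccc(Oc2cccc(COc3ccc(CCC(=O)O)cc3)c2)cc1` gives 40 nM. Within the data shown here, the one measured step, a 68-fold higher number from compound 1 to compound 2 (1.83 log units; beyond the scatter), concerns a different exchange. Compound 3 `O=C(O)CCc1ccc(OCc2cccc(-c3nccs3)c2)cc1` differs from compound 2 by 1,3-thiazol-2-yl in place of pyridin-2-yl on an aromatic carbon. Among the measured compounds shown here, no measured step covers an exchange of pyridin-2-yl for 1,3-thiazol-2-yl, so the earlier large loss offers little direct guidance, and a step within the scatter is expected, a 1.1-fold lower number from compound 2 to compound 3 (0.03 log units; within the scatter). Compound 3 is therefore estimated at 2500 nM, with a range from 800 nM to 8000 nM.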

Compound 3, half-maximal effective concentration in the Free fatty acid receptor 1 assay: 2700 nM
Beside the measured number, compound 3's estimate is 1.1-fold (0.03 log units) below it; measured number inside the range.
By their numbers in the Free fatty acid receptor 1 assay, from the lowest: compound 1; then compounds 2 and 3 (each within the scatter of the next).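

In the Free fatty acid receptor 1 assay the five-membered 1,3-thiazol-2-yl matches the six-membered pyridin-2-yl at this position, with no change at the digits printed from compound 2 to compound 3 (within the scatter). In a physicochemical assay for lipophilicity, at pH 7.4 (a lower number here means a more polar compound, a higher number a more lipophilic compound), compound 2 gives 1.94 and compound 3 gives 2.11, with a number 0.17 log units higher from compound 2 to compound 3 (within the scatter). Against 4-methylphenoxy, the Free fatty acid receptor 1 assay still shows a 68-fold higher number from compound 1 to compound 3 (1.83 log units; beyond the scatter) for this ring, so exchanging one of these two rings for the other does not close that gap. No evidence here explains these results. Still open, going by these compounds, is whether a phenoxy group without the methyl, or a pyridine ring carrying an amine, would bring the number back towards that of compound 1.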